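The source may report more compounds than this note shows. Statements on the series, on what has been measured and on what is new or still open speak of the compounds shown alone.

Measured in an assay for displacement of a labelled ligand from DNA repair protein REV1 (Homo sapiens), read by fluorescence polarization, with a stated time of 1 h, tested at 1 uM; on this read-out lower numbers stand for less inhibition and higher numbers for more inhibition at the one concentration tested (going by the name of the read-out):
compound 1 `CC(=O)N1CCC(C(=O)Nc2sc3c(c2C(=O)NC2CC2)CCC(C)C3)CC1`: 50%
compound 2 `CCc1cc(C(=O)OC)c(NC(=O)C2CCN(C(C)=O)CC2)s1`: 50%
compound 3 `CC(=O)N1CCC(C(=O)Nc2sc3c(c2C(N)=O)CCC(C)C3)CC1`: 50%

On the numbers shown, compound 1 stands level with compound 2 and compound 3 in this assay; the three read-outs lie within the scatter of one another. Among the compounds with values here, the only step with both ends measured, no change at the digits printed from compound 1 to compound 3 (within the scatter), is hydrogen in place of cyclopropyl on an amide-type nitrogen, and it stays within the scatter. Compound 4 `CC(=O)N1CCC(C(=O)Nc2sc3c(c2C(=O)NC2CC2)CCCC3)CC1` is not yet measured. It differs from compound 1 by hydrogen in place of methyl on a saturated ring carbon, the site being a saturated ring carbon of a six-membered non-aromatic ring of carbon only, part of a fused or bridged system of two rings. Within the data shown here, no measured step involves that ring, so the expectation rests only on the level series: no step beyond the scatter is expected, no change at the digits printed from compound 1 to compound 4 (within the scatter). For compound 4 the expected read-out in this assay is 50%, with a range from 35% to 65%.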

Compound 4, a percentage reported as inhibition, at one concentration (the size of the read-out at that concentration, not a potency): 50%
Beside the measured number, compound 4's estimate shows no gap at the digits printed; the measured number falls inside the stated range.
By their numbers in this assay, from the lowest: compounds 1, 2, 3 and 4 (each within the scatter of the next).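

In this assay, hydrogen in place of methyl on a saturated ring carbon gives no change at the digits printed from compound 1 to compound 4 (within the scatter), a read on this ring that the earlier step, on an amide-type nitrogen, did not give. At the one concentration tested, the read-out therefore does not depend on this methyl beyond the scatter. No supporting data bear on this result.

On these data alone, whether an amine or a longer chain on this ring carbon would leave the read-out level remains open. Potency also remains open, since the read-out comes from a single concentration.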